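The source may hold more compounds than are shown below. What is called first, only, known or untested is meant among the compounds shown, and "the series" means these compounds.

Measured compounds:
- compound 1 `[N-]=[N+]=Nc1nccc2c1ncn2[C@H]1C[C@H](O)[C@@H](CO)O1`: 13%
- compound 2 `CSc1nccc2c1ncn2C1O[C@H](CO)[C@@H](O)[C@H]1O`: < 5%
- compound 3 `c1ccc(CSc2[nH]ccc3ncnc2-3)cc1`: 20%

All three were tested in a functional assay on EL4 cells (Mus musculus) for inhibition, tested at 100 uM; on this read-out higher numbers stand for more inhibition at the one concentration tested (going by the name of the read-out) and lower numbers for less inhibition. In this assay compound 1 gives 13%, and compound 3 gives 20%; the gap between these two numbers lies within the usual scatter, so the two numbers count as level. Compound 2 gives only a limit in this assay, < 5%, and that is all that is known of it; the situation is summed up by the limit of < 5% in this assay, at which 1 of the 3 values shown sits. So compound 1 stands among the numbers, not at a limit, with compound 3 close by.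

Compound 4 `OC[C@H]1O[C@@H](n2cnc3cnccc32)C[C@@H]1O` has not yet been measured. It differs from compound 1 in one place: hydrogen in place of azido on an aromatic carbon. The change sits on an aromatic carbon of a six-membered aromatic ring with one nitrogen, part of a fused system of two rings, next to the ring nitrogen.

Among the compounds with values here, with no measured pair showing what such a change does here, the expectation rests on compound 1 alone. The step of a number 3 percentage points lower from compound 1 to compound 4 (within the scatter) is expected to be none beyond the scatter. Compound 4 is therefore estimated to give about 10% in this assay, with a range from 0% to 25%.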

Compound 4, a percentage reported as inhibition, at one concentration (the size of the read-out at that concentration, not a potency): < 5%
Compound 4: no number, only a limit; the forecaster's own chance of this, stated with the estimate: 30%; middle value at least 5 percentage points away from the limit.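

Within the data shown here, replacing the azido group with hydrogen on this aromatic carbon, next to the ring nitrogen, gives the first measured step at this position in this assay, and it reads as a number at least 8 percentage points lower from compound 1 to compound 4 (that floor lies within the scatter). On these data alone, compound 4 gives only a limit, < 5%, so the true size of the step stays unknown, and its floor alone does not carry it beyond the scatter. The result therefore neither establishes nor excludes a contribution of the azido group to inhibition, while more of the compounds now sit at the bottom of the read-out: the limit of < 5% in this assay, at which 2 of the 4 values shown sit.

As far as these compounds go, it remains open whether another group on this carbon, such as an amine, a methoxy group or a chlorine atom, would keep or raise the number. Among these compounds, with only this one pair differing in one place, it is also open whether the same change would act alike elsewhere.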